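Swapping the urea's aryl group on compound 3

This account rests on a few compounds, and the source may have more. Where it says the series, first, only, none or still open, it means among the compounds named here.

Measured compounds:
- compound 1, `Cc1ccc(Nc2cc(NC(=O)Nc3c(Cl)cccc3Cl)ncn2)cc1F`: 85.3%
- compound 2, `COc1cc(NC(=O)Nc2cc(Nc3cc(F)ccc3OC)ncn2)cc(OC)c1`: 59%
- compound 3, `COc1cc(NC(=O)Nc2cc(Nc3cc(C(F)(F)F)ccc3OC)ncn2)cc(OC)c1`: 59.7%

In a functional assay on HCC827 cells (Homo sapiens) for inhibition, read by MTT assay, with a stated time of 48 h, tested at 10 uM (a lower number here means less inhibition, a higher number more inhibition at the concentration tested (going by the name of the read-out)), compound 3 stands second highest of the three numbers. Its nearest neighbour is compound 2, and the step of a number 0.7 percentage points higher from compound 2 to compound 3 (within the scatter) is within the scatter, so the two cannot be told apart. Compound 1 lies furthest away and is beyond the scatter above compound 3, although compound 1 differs from compound 3 in two places at once, so no single step can be read from that pair.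

Compound 4, `COc1ccc(C(F)(F)F)cc1Nc1cc(NC(=O)Nc2c(Cl)cccc2Cl)ncn1`, is not yet measured. The change from compound 3 is 2,6-dichlorophenyl in place of 3,5-dimethoxyphenyl on an amide-type nitrogen. Within the data shown here, no measured step covers exactly this exchange. Among the measured compounds shown here, the only hint is that compound 1, which carries the entering group, gives 85.3% while compound 3 gives 59.7% in this assay. On that basis a rise is expected, with wide uncertainty.

Compound 4 is therefore estimated at 76%, between 60% and 90%. This corresponds to an expected step of a number 16.3 percentage points higher from compound 3 to compound 4 (beyond the scatter).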

Compound 4, a percentage reported as inhibition, at one concentration (the size of the read-out at that concentration, not a potency): 68.7%
For compound 4 the middle estimate is 7.3 percentage points above the measured one; measured number inside the range.
By their numbers in this assay, from the lowest: compounds 2, 3 and 4 (each within the scatter of the next); then compound 1.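

Among these compounds, compound 3 and compound 4 differ only in the aryl group on the amide-type nitrogen of the urea, so this pair gives the first direct reading of a change at that position. In this assay the exchange of 3,5-dimethoxyphenyl for 2,6-dichlorophenyl gives a number 9 percentage points higher from compound 3 to compound 4 (within the scatter) and so the two compounds cannot be told apart, even though a ring carrying chlorine has replaced one carrying methoxy groups. Nothing available here explains this result.

From the compounds shown here alone, it remains open whether a different kind of group on this nitrogen, such as a pyridine ring or a simple butyl chain, would shift the number beyond the scatter. Going by these compounds, it is also open whether 3,5-dimethoxyphenyl on the core of compound 1 would give a larger step than the one seen here.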